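Amide nitrogen variation on the shared core

The source may report more compounds than this note shows. Statements on the series, on what has been measured and on what is new or still open speak of the compounds shown alone.

Three compounds share one core and differ only at an amide-type nitrogen. Compound 1 `O=C(COc1ccc2cc(C(O)(C(F)(F)F)C(F)(F)F)c(O)cc2c1)Nc1nc2ccccc2s1` carries 1,3-benzothiazol-2-yl there; in an assay on isolated protein for inhibition of tyrosine-protein phosphatase non-receptor type 13 (Homo sapiens), read by spectrophotometry (on this read-out lower numbers stand for stronger inhibition and higher numbers for weaker inhibition), compound 1 gives 9900 nM. Compound 2 `Cc1ccc(S(=O)(=O)NNC(=O)COc2ccc3cc(C(O)(C(F)(F)F)C(F)(F)F)c(O)cc3c2)cc1` carries ((4-methylphenyl)sulfonyl)amino instead, and in this assay compound 2 gives 14900 nM. Compound 3 `O=C(COc1ccc2cc(C(O)(C(F)(F)F)C(F)(F)F)c(O)cc2c1)Nc1ccccc1` carries phenyl. For compound 3 the result in this assay is a limit of the assay, > 20000 nM, so compound 3 sits at the limit of > 20000 nM in this assay, at which 1 of the 3 values shown sits, and no number is known for it. The steps among these three stay within the scatter: a 1.5-fold higher number from compound 1 to compound 2 (0.18 log units; within the scatter), an at least 2.0-fold higher number from compound 1 to compound 3 (0.30 log units; that floor lies within the scatter) and an at least 1.3-fold higher number from compound 2 to compound 3 (0.12 log units; that floor lies within the scatter). Compound 3 thus stands at the limit, with nothing to separate it from compound 1 or compound 2 beyond the scatter.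

Compound 4 `O=C(COc1ccc2cc(C(O)(C(F)(F)F)C(F)(F)F)c(O)cc2c1)N(c1ccccc1)c1ccccc1` differs from compound 3 by phenyl in place of hydrogen on an amide-type nitrogen. The three measured steps all exchange the group on this same nitrogen, and none of them moved the read-out beyond the scatter, so the expectation for this assay is a step that the limit leaves unreadable from compound 3 to compound 4, most likely ending again at the limit. Compound 4 is therefore expected to give 30000 nM in this assay, within 12000 nM to 80000 nM.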

Compound 4, half-maximal inhibitory concentration: 12400 nM
Beside the measured number, compound 4's estimate is 2.4-fold (0.38 log units) above it; the range from low to high includes it.
By their numbers in this assay, from the lowest: compounds 1, 4 and 2 (each within the scatter of the next). At a limit, above all of these: compound 3.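

Compound 3 has a limit of the assay and not a number: the limit of > 20000 nM in this assay, at which 1 of the 4 values shown sits.
In this assay phenyl in place of hydrogen on the amide-type nitrogen gives an at least 1.6-fold lower number from compound 3 to compound 4 (0.20 log units; that floor lies within the scatter) and so only a floor is known for this change, one that does not separate the two compounds. The new information is that compound 4 carries no amide hydrogen on this nitrogen and still returns a measured number, something compounds 1, 2 and 3 could not show, as all three keep that hydrogen.

Open, on these data alone, is whether a methyl or a benzyl on this nitrogen in place of hydrogen would also return a number, which would help tell what belongs to the second phenyl itself and what to the loss of the amide hydrogen. Open too, as far as these compounds go, is the true size of this step, which stays unreadable as long as compound 3 is known only as a limit, and so is any ordering of the hydrogen and phenyl forms on this nitrogen.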